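Hydrazone aryl swap on the shared core

A few compounds are considered here, and "the series" means these few. Any claim that something is new, unique, unknown or untested is made for them only; others in the source may bear on it.

Compound 1 `CCCSc1nc(N/N=C/c2cccc(Cl)c2)c2nnn(Cc3ccccc3)c2n1` is measured only as a limit in a functional assay on ECa-109 cells (Homo sapiens) for antiproliferative activity, read by MTT assay, with a stated time of 72 h (a higher number here means a weaker inhibitor, a lower number a stronger inhibitor), where compound 1 gives > 64000 nM. Its position is set by the limit of > 64000 nM in this assay, at which 1 of the 2 values shown sits, so no number is available for it. Compound 2 `CCCSc1nc(N/N=C(\C)c2ccccc2)c2nnn(Cc3ccccc3)c2n1` gives 32200 nM in this assay. The step of an at least 1.9-fold lower number from compound 1 to compound 2 (0.29 log units; that floor lies within the scatter) is the only measured one in the series, and its floor lies within the scatter.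

Compound 3 `CCCSc1nc(N/N=C/c2c(O)ccc3ccccc23)c2nnn(Cc3ccccc3)c2n1` differs from compound 1 by 2-hydroxynaphthalen-1-yl in place of 3-chlorophenyl on a carbon with a double bond to nitrogen. The measured step from compound 1 to compound 2 bears on it only loosely: it also alters the group at the hydrazone end, and it shows nothing beyond the scatter. With compound 1 known only as a limit, no direction for compound 3 can be read from the two values. Compound 3 is therefore expected to sit near the limit of compound 1, with a step of an at least 1.4-fold lower number from compound 1 to compound 3 (0.15 log units; that floor lies within the scatter) that is not expected to clear the scatter. The estimate for compound 3 in this assay is 45000 nM, expected between 12000 nM and 170000 nM, with a fair chance that only a limit is returned.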

Compound 3, half-maximal inhibitory concentration: 9290 nM
Compound 3: middle estimate off by 4.8-fold (0.69 log units), on the high side; measured number below the stated range.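

In this assay, the carbon with a double bond to nitrogen proves sensitive to its aryl group: 2-hydroxynaphthalen-1-yl in place of 3-chlorophenyl gives an at least 6.8-fold lower number from compound 1 to compound 3 (0.83 log units; beyond the scatter), the only step shown that clears the scatter. The earlier step to compound 2 could not show this, since its floor stayed within the scatter, so this position on the shared core now has a measured response to a single change. The value of compound 1 is a limit, and the true size of the step stays unknown because only a floor can be read: the limit of > 64000 nM in this assay, at which 1 of the 3 values shown sits.

The change brings in a second aromatic ring and a hydroxyl group together, so the compounds shown do not say which of the two carries the step; 2-hydroxyphenyl and naphthalen-1-yl at this place would separate them. Also open, from the compounds shown here alone, is whether the hydroxyl group must be a hydroxyl at all, as a methoxy group or an amine on the same naphthalene would test.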